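A few compounds are considered here, and "the series" means these few. Any claim that something is new, unique, unknown or untested is made for them only; others in the source may bear on it.

In an ADME assay on S9 fraction from liver (Mus musculus) for metabolic stability, read by LC-MS, using NADPH, with a stated time of 60 min, tested at 1 uM (a lower number here means that the compound disappears faster, a higher number that the compound lasts longer), compound 1 (`Cc1ccccc1N(C)C(=O)c1ccc(-c2ccc(OS(N)(=O)=O)cc2)o1`) gives 0.417 h and compound 2 (`Cc1ccc(F)cc1N(C)C(=O)c1ccc(-c2ccc(OS(N)(=O)=O)cc2)o1`) gives 0.065 h as the lower of the two numbers. Compound 3 (`Cc1cc(F)ccc1N(C)C(=O)c1ccc(-c2ccc(OS(N)(=O)=O)cc2)o1`) differs from compound 2 by 4-fluoro-2-methylphenyl in place of 5-fluoro-2-methylphenyl on an amide-type nitrogen, with 4-fluoro-2-methylphenyl in place of 5-fluoro-2-methylphenyl on an amide-type nitrogen. For the measured compounds named here, only one measured step bears on this: a 6.4-fold lower number from compound 1 to compound 2 (0.81 log units; beyond the scatter), a modest step on adding the fluoro. Going by the values given here, no measured step moves the fluoro, so the direction is uncertain. A partial recovery is expected, estimated as a 2.6-fold higher number from compound 2 to compound 3 (0.42 log units; beyond the scatter) in this assay. For compound 3 the estimate is 0.17 h, with 0.05 h to 0.5 h as the expected range.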

Compound 3, half-life: 0.0767 h
Beside the measured number, compound 3's estimate is 2.2-fold (0.35 log units) above it, within the range that was stated.
By their numbers in this assay, from the lowest: compounds 2 and 3 (each within the scatter of the next); then compound 1.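

In this assay, 4-fluoro-2-methylphenyl in place of 5-fluoro-2-methylphenyl on the amide-type nitrogen gives a 1.2-fold higher number from compound 2 to compound 3 (0.07 log units; within the scatter), so these two fluoro placements cannot be told apart here. Compared with the compound without fluoro, the new placement gives a 5.4-fold lower number from compound 1 to compound 3 (0.74 log units; beyond the scatter), so the shorter half-life is seen with both fluoro placements. No measurement here gives a reason for this. Still open, as far as these compounds go, is how chloro or a nitrile in place of the fluoro would read in this assay, and whether either would retain the half-life of compound 1.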